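This account rests on a few compounds, and the source may have more. Where it says the series, first, only, none or still open, it means among the compounds named here.

The shared core of compound 3 `CCn1cc(C(=O)O)c(=O)c2cc(F)c(N3CCN(/C=N/NC(=O)c4ccc(C(F)(F)F)cc4)CC3)cc21` carries an ethyl on an aromatic nitrogen, where compound 2 `O=C(N/N=C/N1CCN(c2cc3c(cc2F)c(=O)c(C(=O)O)cn3C2CC2)CC1)c1ccc(C(F)(F)F)cc1` carries a cyclopropyl. In an ADME assay on HepG2 cells (Homo sapiens) for cytotoxicity, read by MTT assay (a lower number here means a stronger inhibitor, a higher number a weaker inhibitor), compound 2 gives 347000 nM. For compound 3 this assay reports only a limit, > 37300 nM. The step that the limit leaves unreadable from compound 2 to compound 3 therefore cannot be sized. Compound 1 `O=C(O)c1ccc(N/C=N/NC(=O)c2ccccc2F)cc1O`, which differs in several places at once, gives 1210000 nM in this assay. Compound 4 `CCn1cc(C(=O)O)c(=O)c2cc(F)c(N3CCN(/C=N/NC(=O)c4cccc(F)c4)CC3)cc21` differs from compound 3 by 3-fluorophenyl in place of 4-(trifluoromethyl)phenyl on a carbonyl carbon. Within the data shown here, no measured pair shows this exchange, and the limit of > 37300 nM in this assay, at which 1 of the 3 values shown sits, leaves compound 3 itself unplaced, so no direction can be read. The expected step is a step that the limit leaves unreadable from compound 3 to compound 4. Compound 4 is expected near 100000 nM, within 37300 nM to 400000 nM, and may well be reported only as a limit again.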

Compound 4, half-maximal inhibitory concentration: > 393000 nM
Compound 4 gave a limit, no number (the forecaster's own chance of this, stated with the estimate: 50%); middle value at least 3.9-fold (0.59 log units) from the limit.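

Compound 3 and compound 4 are both reported only as limits in this assay, and the step between them cannot be read. The compounds shown leave open how 3-fluorophenyl and 4-(trifluoromethyl)phenyl on a carbonyl carbon compare.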